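The source may hold more compounds than are shown below. What is called first, only, known or untested is meant among the compounds shown, and "the series" means these compounds.

Within the data shown here, compound 2 `CCCCN(CCCC)Cc1cn(C2CCCCC2O)nn1` gives 32% in an assay on nucleic acid for inhibition of Nucleic Acid, read by fluorescence, tested at 100 uM (a lower number here means less inhibition, a higher number more inhibition at the concentration tested (going by the name of the read-out)), the highest of the three numbers measured so far. The nearest to it is compound 3 `O=C(NCc1ccccc1)OCC(O)Cn1cc(CN2CCC(c3ccccc3)CC2)nn1`, which gives 29% in this assay, a number only a few points lower and within the usual scatter of such measurements, so the two cannot be ranked against each other. Furthest away is compound 1 `O=C(OCC(O)Cn1cc(CN2CCN(c3ccccc3)CC2)nn1)c1ccccc1`, which gives 11% in this assay; its distance from compound 2 lies beyond the scatter. Among the measured compounds shown here, no two of the measured compounds differ in a single place, so no step between them can be drawn from the data.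

Compound 4 `CCCCN(CCCC)Cc1cn(C2CCCCC2OC(=O)COc2ccccc2)nn1` has not yet been measured. It is derived from compound 2 by one change: (phenoxymethyl)carbonyl in place of hydrogen on an oxygen on a saturated carbon. In the absence of any measured step that resembles this change, the account can only reason from the number of compound 2. The hydroxyl of compound 2 is replaced by an ester-bearing group, and the two measured compounds that carry an ester or carbamate on an oxygen show numbers both above and well below each other, giving no consistent direction.

Compound 4 is therefore expected to land close to the number of compound 2, with the step from compound 2 to compound 4 estimated as a number 2 percentage points higher from compound 2 to compound 4 (within the scatter), no direction beyond the scatter being claimed. The estimate for compound 4 in this assay is 34%, with a range from 14% to 56%.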

Compound 4, a percentage reported as inhibition, at one concentration (the size of the read-out at that concentration, not a potency): 26%
The estimate for compound 4 lay 8 percentage points above the measured number; the range from low to high includes it.
By their numbers in this assay, from the lowest: compound 1; then compounds 4, 3 and 2 (each within the scatter of the next).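

In this assay, among these compounds, the step at this position is a number 6 percentage points lower from compound 2 to compound 4 (within the scatter), the first step between measured compounds that differ in one place. It shows that the hydrogen on this oxygen on a saturated carbon can give way to (phenoxymethyl)carbonyl, a group of 10 heavy atoms with one six-membered aromatic ring, without a step beyond the scatter, so this single pair gives no sign that the read-out depends on that hydrogen or on the added group. Nothing available explains this outcome, and a single pair within the scatter gives no direction for this change.

The compounds shown leave open whether a smaller group on the same oxygen, such as acetyl or methyl, or one ending in a carboxylic acid or an amine, would stay within the scatter of compound 2 or move beyond it. They also leave open whether (phenoxymethyl)carbonyl would give a similar step on the oxygen that still carries its hydrogen in compound 3, whose core and amine part are different.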